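This account rests on a few compounds, and the source may have more. Where it says the series, first, only, none or still open, it means among the compounds named here.

Measured compounds:
compound 1, `CCn1c(NC2CCOCC2)nc2ccsc2c1=O` — 37 ug/mL
compound 2, `CCn1c(NC2CCC2)nc2ccsc2c1=O` — 6.3 ug/mL
compound 3, `CCn1c(NC(C)C)nc2c(-c3cccnc3)csc2c1=O` — 5.8 ug/mL

In a physicochemical assay for solubility, in phosphate buffer, at pH 6.8 (a higher number here means a more soluble compound, a lower number a less soluble compound), compound 3 gives the lowest of the three numbers. Its nearest neighbour is compound 2, and the two values lie within the scatter of each other, so nothing separates them. Compound 1 stands furthest from compound 3, beyond the scatter.

Compound 4, `CCn1c(NC(C)C)nc2c(C3CCNCC3)csc2c1=O`, has not yet been measured in this assay. It differs from compound 3 in one place: piperidin-4-yl in place of pyridin-3-yl on an aromatic carbon.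

Only one measured step exists among these compounds, a 5.9-fold lower number from compound 1 to compound 2 (0.77 log units; beyond the scatter), and it concerns a change on a nitrogen on an aromatic ring, not on the aromatic carbon of the five-membered ring where compound 4 differs from compound 3. For the measured compounds named here, no measured pair therefore bears directly on the present change; the replacement of one six-membered ring by another that carries a hydrogen-bond donor has no counterpart among compounds 1 to 3.

With that caveat, the expectation for this assay is a step upward, a 10-fold higher number from compound 3 to compound 4 (1.01 log units; beyond the scatter). Compound 4 is estimated at 60 ug/mL, with a range from 15 ug/mL to 250 ug/mL.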

Compound 4, solubility: 1100 ug/mL
Compound 4: middle estimate off by 18-fold (1.26 log units), on the low side; measured number above the stated range.
By their numbers in this assay, from the lowest: compounds 3 and 2 (each within the scatter of the next); then compound 1; then compound 4.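

In this assay, the aromatic carbon of the five-membered ring, two ring bonds from the ring sulfur, turns out to be a place where a single change can move the number a long way: piperidin-4-yl in place of pyridin-3-yl gives a 190-fold higher number from compound 3 to compound 4 (2.28 log units; beyond the scatter), a far larger step than the only earlier one, a 5.9-fold lower number from compound 1 to compound 2 (0.77 log units; beyond the scatter), which concerned a group on a nitrogen. The two groups match in heavy atoms and hydrogen-bond acceptors, and neither carries a net charge as counted, so the step goes with a change from an aromatic to a non-aromatic ring and with the gain of a hydrogen-bond donor. No supporting measurement is available that accounts for the size of this step.

The compounds shown do not separate those two features, which change together between compound 3 and compound 4. Cyclohexyl or oxan-4-yl on the same aromatic carbon, or a methyl group on the piperidine nitrogen, would bear on that question, and it remains open whether the step would carry over to compounds with another group on the exocyclic nitrogen, such as oxan-4-yl or cyclobutyl.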